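Nitro to methoxy on the aryl of compound 2

A few compounds are considered here, and "the series" means these few. Any claim that something is new, unique, unknown or untested is made for them only; others in the source may bear on it.

Measured compounds:
compound 1, `CCOC(=O)c1sc(NC(=O)Cn2cc(-c3cccs3)nn2)nc1C`, in a functional assay on BMDM cells (Mus musculus, strain C57BL/6) for inhibition, with a stated time of 2 days (a higher number here means a weaker inhibitor, a lower number a stronger inhibitor), compound 1 gives 20 nM
compound 2, `O=C(Cn1cc(-c2ccc([N+](=O)[O-])cc2)nn1)Nc1nccs1`, compound 2 gives 1040 nM
compound 3, `CCOC(=O)c1sc(NC(=O)Cn2cc(-c3ccc(F)cc3)nn2)nc1C`, compound 3 gives 660 nM

Compound 2 stands at the highest of the three numbers in this assay. Its nearest neighbour is compound 3, which lies within the scatter of it, so no order between compound 2 and compound 3 can be claimed; compound 1 lies far lower, beyond the scatter.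

Compound 4, `COc1ccc(-c2cn(CC(=O)Nc3nccs3)nn2)cc1`, is the next member and has not been measured. It differs from compound 2 in one place: methoxy in place of nitro on an aromatic carbon

For the measured compounds named here, the one measured step, a 33-fold higher number from compound 1 to compound 3 (1.52 log units; beyond the scatter), exchanges a whole aromatic group on a different core and leaves no substituent on a six-membered aromatic ring of carbon only. Going by the values given here, it is large, but it does not bear on a nitro-to-methoxy exchange, and no pair in the set compares two groups on such a ring. The expectation therefore rests on compound 2 alone.

Without a bearing step, the estimated change is a 1.2-fold lower number from compound 2 to compound 4 (0.06 log units; within the scatter), that is, no step beyond the scatter is expected. Compound 4 is estimated at 900 nM, with a range from 250 nM to 3500 nM. The range is wide because compound 2 alone guides it with 1040 nM.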

Compound 4, half-maximal inhibitory concentration: 510 nM
For compound 4 the middle estimate is 1.8-fold (0.25 log units) above the measured one; measured number inside the range.
By their numbers in this assay, from the lowest: compound 1; then compounds 4, 3 and 2 (each within the scatter of the next, the first and the last beyond it).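

In this assay, for the compounds shown here, methoxy in place of nitro on an aromatic carbon para to a large group gives a 2.0-fold lower number from compound 2 to compound 4 (0.31 log units; beyond the scatter) and so provides the first measured exchange of one substituent for another on a six-membered aromatic ring of carbon only. This modest step shows that the number at this position does respond to the group placed there, although on a much smaller scale than the exchange of a whole aromatic group on the core of compound 1, which gives a 33-fold higher number from compound 1 to compound 3 (1.52 log units; beyond the scatter) in a different setting. No measurement on hand accounts for the change from nitro to methoxy, and the step itself gives no reason for it.

From the compounds shown here alone, this single pair defines no trend at the position, and how an amine, a carboxylic acid or a longer chain such as ethoxy would sit relative to methoxy and nitro remains open. Also open, going by these compounds, is whether the exchange would give a step of similar size and direction on the core of compound 1, which carries the ethyl ester and the methyl group absent from compound 2 and compound 4.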